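Working notes: aminomethyl analogue of compound 3

The source may hold more compounds than are shown below. What is called first, only, known or untested is meant among the compounds shown, and "the series" means these compounds.

Measured compounds, with values in a functional assay on K562 cells (Homo sapiens) for cytotoxicity, read by MTT assay, with a stated time of 24 h; a lower number here means a stronger inhibitor, a higher number a weaker inhibitor:
- compound 1 `OCc1cc2ccccc2nc1-c1ccccc1O`: 74000 nM
- compound 2 `OCc1cc2cc(Cl)ccc2nc1-c1ccccc1O`: 11000 nM
- compound 3 `[N-]=[N+]=NCc1cc2ccccc2nc1-c1ccccc1O`: 11000 nM

Compound 3 and compound 2 stand level at the digits shown and together give the lowest numbers of the three. Compound 1 gives the highest; the step of a 6.7-fold lower number from compound 1 to compound 3 (0.83 log units; beyond the scatter) is beyond the scatter, as is a 6.7-fold lower number from compound 1 to compound 2 (0.83 log units; beyond the scatter).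

Compound 4 `NCc1cc2ccccc2nc1-c1ccccc1O` differs from compound 3 by amino in place of azido on a saturated chain carbon bound to an aromatic carbon. For the measured compounds named here, no measured step covers an azido to amino exchange. Going by the values given here, the only step that bears on it is a 6.7-fold lower number from compound 1 to compound 3 (0.83 log units; beyond the scatter), which shows that what sits on this saturated chain carbon shifts the number by a modest amount; compound 1, carrying hydroxy there, and compound 3, carrying azido, span the whole range of the series. The step of a 6.7-fold lower number from compound 1 to compound 2 (0.83 log units; beyond the scatter) sits at another position and does not inform the change. Amino shares a hydrogen-bond donor with the hydroxy of compound 1 and shares nothing of the azido beyond the point of attachment, so a move back toward compound 1 is as plausible as no change. Compound 4 is therefore expected to give a modest upward step a 2.3-fold higher number from compound 3 to compound 4 (0.36 log units; beyond the scatter), with wide uncertainty. The estimate for compound 4 is 25000 nM, within 7000 nM to 90000 nM.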

Compound 4, half-maximal inhibitory concentration: 23000 nM
For compound 4 the middle estimate is 1.1-fold (0.04 log units) above the measured one, and the stated range covers the measured number.
By their numbers in this assay, from the lowest: compounds 2 and 3 (each within the scatter of the next); then compound 4; then compound 1.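

In this assay the saturated chain carbon bound to an aromatic carbon now carries a third group, and amino reads apart from both of the others: a 2.1-fold higher number from compound 3 to compound 4 (0.32 log units; beyond the scatter) and a 3.2-fold lower number from compound 1 to compound 4 (0.51 log units; beyond the scatter) are each beyond the scatter. For the compounds shown here, the position therefore gives three separate levels across hydroxy, amino and azido, with amino in the middle, where the earlier compounds gave only the two ends of the range and no direct azido to amino step. Azidomethyl to aminomethyl also removes part of the gain seen on going from hydroxy to azido without removing all of it, but nothing at hand accounts for this order of the three groups.

Still open, on these data alone, is how other groups on this carbon would read, such as a dimethylamino group, an acetamide or a carboxylic acid, or a longer chain carrying the amine. Also open, as far as these compounds go, is whether the chloro exchange on the aromatic carbon, seen in a 6.7-fold lower number from compound 1 to compound 2 (0.83 log units; beyond the scatter) with hydroxy on the chain, would shift the number in the same way with amino or azido there.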